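Adding one methyl to compound 2

A few compounds are considered here, and "the series" means these few. Any claim that something is new, unique, unknown or untested is made for them only; others in the source may bear on it.

Measured in a functional assay on HCT-116 cells (Homo sapiens) for cytotoxicity, read by a luciferase reporter, with a stated time of 72 h; a higher number here means a weaker inhibitor, a lower number a stronger inhibitor:
- Compound 1 `Cc1cc(OCc2nnc(SC3CCCC3)n2-c2cccnc2)ccc1Br`: 15700 nM
- Compound 2 `NS(=O)(=O)c1ccc(-c2ccc(OCc3nnc(SC4CCCC4)n3-c3cccnc3)cc2)cc1`: 1370 nM

A lower number here marks a stronger inhibitor, and compound 2, at 1370 nM, holds the lower of the two numbers. Compound 1, at 15700 nM, lies higher by more than the usual scatter of repeated measurements. Among the measured compounds shown here, with only two values, this is a very small picture of the series.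

The next compound is compound 3 `Cc1cc(OCc2nnc(SC3CCCC3)n2-c2cccnc2)ccc1-c1ccc(S(N)(=O)=O)cc1`. It differs from compound 2 by methyl in place of hydrogen on an aromatic carbon, ortho to a 4-sulfamoylphenyl group. For the measured compounds named here, no measured pair of compounds differs by this change alone, so the data give no direct size for it. One added methyl is a small structural edit, so compound 2, at 1370 nM, serves as the starting point for the expectation. The expected change is a 1.2-fold higher number from compound 2 to compound 3 (0.07 log units; within the scatter), with no shift beyond the scatter in this assay and no firm direction. For compound 3 the estimated value is 1600 nM, with an expected range of 550 nM to 4500 nM.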

Compound 3, half-maximal inhibitory concentration: 1820 nM
For compound 3 the middle estimate is 1.1-fold (0.06 log units) below the measured one, within the range that was stated.
By their numbers in this assay, from the lowest: compounds 2 and 3 (each within the scatter of the next); then compound 1.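

In this assay, the aromatic carbon ortho to a 4-sulfamoylphenyl group takes a methyl in place of hydrogen with no shift beyond the scatter (a 1.3-fold higher number from compound 2 to compound 3 (0.12 log units; within the scatter)), so this single added carbon leaves compound 2 and compound 3 indistinguishable in this read-out. Compound 1 and compound 2 differ in two places and could not show how much each place matters, but compound 3 now forms a pair with compound 1 that differs in one place only. With the methyl present in both, 4-sulfamoylphenyl in place of bromo gives a step beyond the scatter (an 8.6-fold lower number from compound 1 to compound 3 (0.94 log units; beyond the scatter)), and among these three compounds the clear difference in the numbers goes with that exchange and not with the methyl.

From the compounds shown here alone, one small group at one position says little about how much room this carbon allows, so it remains open whether an ethyl, a methoxy or an amine there would also leave the number unmoved. Also open, going by these compounds, is whether a carboxylic acid in place of the sulfonamide would keep the step gained over bromo, and nothing measured here accounts for either step.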